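A few compounds are considered here, and "the series" means these few. Any claim that something is new, unique, unknown or untested is made for them only; others in the source may bear on it.

Measured compounds:
compound 1 `O=C(O)CCc1ccc(C#CC2CCCC2)cc1` with 490 nM
compound 2 `C=C(C)C#Cc1ccc(CCC(=O)O)c(F)c1` with 81.3 nM
compound 3 `O=C(O)CCc1ccc(C#CCc2ccccc2)cc1` with 389 nM

In a functional assay on 1321-N1 cells for agonist activity at Free fatty acid receptor 1 (Homo sapiens), read by calcium flux, with a stated time of 0.4 s (a higher number here means that more compound is needed for the effect, a lower number that less compound is needed), compound 1 gives the highest of the three numbers. The number of compound 3 lies within the scatter of that of compound 1, so no order between them can be claimed; compound 2 stands beyond the scatter, with the lowest number of the three. Among the measured compounds shown here, no two of the measured compounds differ in a single place, so no measured step is available to guide the next one.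

Compound 4 `O=C(O)CCc1ccc(C#CC2=CCCCC2)cc1` differs from compound 1 by cyclohex-1-en-1-yl in place of cyclopentyl on a triple-bonded carbon. Without a measured step of this kind, only a modest change is expected for compound 4, with the step of a 1.4-fold lower number from compound 1 to compound 4 (0.15 log units; within the scatter) estimated to stay close to the scatter. Compound 4 is therefore expected to give 350 nM, between 140 nM and 900 nM.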

Compound 4, half-maximal effective concentration: 200 nM
For compound 4 the middle estimate is 1.8-fold (0.24 log units) above the measured one, and the stated range covers the measured number.
By their numbers in this assay, from the lowest: compound 2; then compounds 4, 3 and 1 (each within the scatter of the next, the first and the last beyond it).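

In this assay, the group on the triple-bonded carbon now has a measured effect: cyclohex-1-en-1-yl in place of cyclopentyl gives a 2.5-fold lower number from compound 1 to compound 4 (0.39 log units; beyond the scatter). Among the compounds shown here, this is the first single-place step available, and it shows that a change at this position alone can move the number beyond the scatter. No evidence at hand accounts for the step.

The change swaps a five-membered ring for a six-membered one and adds a double bond at once, so the compounds shown leave open which of the two matters. A cyclohexyl or cyclopent-1-en-1-yl group on the same carbon would separate them.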